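The source may report more compounds than this note shows. Statements on the series, on what has been measured and on what is new or still open speak of the compounds shown alone.

Compound 1 `CN1CCN(c2ccc(C3=NN(C(=O)CCCl)C(c4ccc(N(C)C)cc4)C3)cc2)CC1`: 2.4%
Compound 2 `Cc1ccc(C(=O)N2N=C(c3ccc(N4CCN(C)CC4)cc3)CC2c2ccc(N(C)C)cc2)cc1`: -0.7%

In a functional assay on MDA-MB-231 cells (Homo sapiens) for inhibition, read by sulforhodamine B assay, tested at 10 uM (on this read-out lower numbers stand for less inhibition and higher numbers for more inhibition at the one concentration tested (going by the name of the read-out)), compound 1 gives 2.4% and compound 2 gives -0.7%. Compound 2 stands lowest of the two numbers, its nearest neighbour being compound 1, though the step of a number 3.1 percentage points lower from compound 1 to compound 2 (within the scatter) lies within the scatter, so the two values cannot be ordered. Compound 3 `CN1CCN(c2ccc(C3=NN(C(=O)c4ccc(C(F)(F)F)cc4)C(c4ccc(N(C)C)cc4)C3)cc2)CC1` differs from compound 2 by trifluoromethyl in place of methyl on an aromatic carbon. Among the compounds with values here, no measured step touches this same change; the one measured step, a number 3.1 percentage points lower from compound 1 to compound 2 (within the scatter), concerns a different part of the shared core and is itself within the scatter. Both measured compounds sit near zero inhibition at the single concentration tested, and nothing among them points to a shift beyond the scatter. Compound 3 is therefore expected to give about 2%, between -8% and 14%, an estimated step of a number 2.7 percentage points higher from compound 2 to compound 3 (within the scatter) that stays within the scatter.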

Compound 3, a percentage reported as inhibition, at one concentration (the size of the read-out at that concentration, not a potency): 55.4%
Compound 3: middle estimate off by 53.4 percentage points, on the low side; the measured number lies above the stated range.
By their numbers in this assay, from the lowest: compounds 2 and 1 (each within the scatter of the next); then compound 3.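

The step of a number 56.1 percentage points higher from compound 2 to compound 3 (beyond the scatter) in this assay shows that this aromatic carbon, para to a large group, is not indifferent to what it carries: a single exchange of methyl for trifluoromethyl separates compound 3 from compound 2, whereas the earlier step had stayed within the scatter. The step of a number 53 percentage points higher from compound 1 to compound 3 (beyond the scatter) adds that 4-(trifluoromethyl)phenyl on the carbonyl also stands apart from 2-chloroethyl, so among these three compounds only this group gives a read-out beyond the scatter of the others. No available information explains the change.

From the compounds shown here alone, it remains open whether the jump is particular to trifluoromethyl or is shared by other groups at this place, such as chlorine, a nitrile or a methoxy group. Going by these compounds, how compound 3 would behave at other concentrations also remains open.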